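Replacing the 2,5-dimethoxyphenyl group of compound 2

This account rests on a few compounds, and the source may have more. Where it says the series, first, only, none or still open, it means among the compounds named here.

Compound 1 `COc1ccc(/C=C/C(=O)Nc2cc3c(Nc4ccc(F)c(Cl)c4)ncnc3cc2O[C@H]2CCOC2)c(OC)c1`: 2760 nM
Compound 2 `COc1ccc(OC)c(/C=C/C(=O)Nc2cc3c(Nc4ccc(F)c(Cl)c4)ncnc3cc2O[C@H]2CCOC2)c1`: 8730 nM

In a functional assay on PC-3 cells (Homo sapiens) for cytotoxicity, read by MTT assay, with a stated time of 72 h (a lower number here means a stronger inhibitor, a higher number a weaker inhibitor), compound 2 stands highest of the two measured compounds. Compound 3 `O=C(/C=C/c1ccc(F)cc1Cl)Nc1cc2c(Nc3ccc(F)c(Cl)c3)ncnc2cc1O[C@H]1CCOC1` differs from compound 2 in one place: 2-chloro-4-fluorophenyl in place of 2,5-dimethoxyphenyl on a double-bonded chain carbon bound to a double-bonded chain carbon. Going by the values given here, the only measured step, a 3.2-fold higher number from compound 1 to compound 2 (0.50 log units; beyond the scatter), exchanges one dimethoxyphenyl group for another, and no measured compound carries 2-chloro-4-fluorophenyl at this place, so that step guides only the expected size. With compound 1 at 2760 nM, a modest move to a lower number is expected. The estimated change is a 2.2-fold lower number from compound 2 to compound 3 (0.34 log units; beyond the scatter). For compound 3 the estimated value is 4000 nM, with an expected range of 1200 nM to 13000 nM.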

Compound 3, half-maximal inhibitory concentration: 7150 nM
Compound 3: the middle estimate sits 1.8-fold (0.25 log units) below what was measured; measured number inside the range.
By their numbers in this assay, from the lowest: compound 1; then compounds 3 and 2 (each within the scatter of the next).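

In this assay, the step of a 1.2-fold lower number from compound 2 to compound 3 (0.09 log units; within the scatter) shows that 2-chloro-4-fluorophenyl, which has no methoxy groups, cannot be told apart from 2,5-dimethoxyphenyl at this place. The step of a 2.6-fold higher number from compound 1 to compound 3 (0.41 log units; beyond the scatter) leaves compound 1 the strongest of the three, so 2,4-dimethoxyphenyl stands apart from both other groups, and methoxy groups alone do not set the number. No supporting data bear on why these numbers fall as they do. Open, from the compounds shown here alone, is how an unsubstituted phenyl, a pyridine ring or a single methoxy group would compare at this place.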